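This account rests on a few compounds, and the source may have more. Where it says the series, first, only, none or still open, it means among the compounds named here.

Notes on the sulfone series. In an ADME assay on microsomes from liver (Homo sapiens) for metabolic stability, tested at 2.5 uM (on this read-out higher numbers stand for fast clearance and lower numbers for slow clearance), compound 1 `Cc1ccc(S(=O)(=O)c2cnc3cc(F)ccc3c2-c2ccc(F)cc2)cc1C` gives 9.25 mL/min, compound 2 `O=S(=O)(c1cc(F)cc(F)c1)c1cnc2cc(F)ccc2c1-c1cccc(Cl)c1` gives 0.22 mL/min, and compound 3 `O=S(=O)(c1cc(Cl)cc(Cl)c1)c1cnc2cc(F)ccc2c1-c1cccc(Cl)c1` gives 0.93 mL/min. On these numbers compound 3 stands second highest of the three, nearer compound 2 than compound 1. Among the measured compounds shown here, the only measured step, a 4.2-fold higher number from compound 2 to compound 3 (0.63 log units; beyond the scatter), alters the group on the sulfonyl sulfur, the same place changed in compound 4 `Cc1ccc(S(=O)(=O)c2cnc3cc(F)ccc3c2-c2cccc(Cl)c2)cc1C`: 3,4-dimethylphenyl in place of 3,5-dichlorophenyl on a sulfonyl sulfur. Compound 1, which also carries 3,4-dimethylphenyl on the sulfonyl sulfur, has the highest number of the three, but compound 1 and compound 4 differ elsewhere as well, so its value is only a pointer. In this assay a rise beyond the scatter is therefore expected, a 5.4-fold higher number from compound 3 to compound 4 (0.73 log units; beyond the scatter). For compound 4 the estimate is 5 mL/min, ranging from 1.5 mL/min to 15 mL/min.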

Compound 4, intrinsic clearance in a liver preparation (reported as CLH), per the amount of preparation that the assay uses: 4.01 mL/min
Beside the measured number, compound 4's estimate is 1.2-fold (0.10 log units) above it; low and high end bracket the measured number.
By their numbers in this assay, from the lowest: compound 2; then compound 3; then compound 4; then compound 1.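

With the 3-chlorophenyl group held, the group on the sulfonyl sulfur moves the number further in this assay (a 4.3-fold higher number from compound 3 to compound 4 (0.63 log units; beyond the scatter); an 18-fold higher number from compound 2 to compound 4 (1.26 log units; beyond the scatter)), and 3,4-dimethylphenyl reads highest of the three groups compared there. With 3,4-dimethylphenyl held, the other place also counts (a 2.3-fold lower number from compound 1 to compound 4 (0.36 log units; beyond the scatter)), where 3-chlorophenyl stands in place of 4-fluorophenyl on an aromatic carbon. No measurement shown bears on the reason for these steps. Open, going by these compounds, is how an amine or a carboxylic acid on the sulfonyl-bound group would read, and whether the order of the three groups holds with 4-fluorophenyl on the aromatic carbon.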